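The source may hold more compounds than are shown below. What is called first, only, known or untested is meant among the compounds shown, and "the series" means these compounds.

In a functional assay on A2780 cells (Homo sapiens) for antiproliferative activity, read by MTT assay, with a stated time of 48 h (on this read-out lower numbers stand for stronger inhibition and higher numbers for weaker inhibition), compound 1 (`COc1ccc(C(=O)c2ccc(OC)c3c2C=CC(C)(C)O3)c(NC(=O)CBr)c1`) gives 2150 nM and compound 2 (`COc1ccc(C(=O)c2ccc3c(c2)C=CC(C)(C)O3)c(NC(=O)CBr)c1`) gives 1870 nM, two values within the scatter of each other. Compound 3 (`COc1ccc(C(=O)c2ccc(OC)c3c2C=CC(C)(C)O3)c(NC(=O)CO)c1`) gives 420 nM, so compound 2 stands with compound 1 at the high end of the three numbers, clearly above compound 3.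

Compound 4 (`COc1ccc(C(=O)c2ccc3c(c2)C=CC(C)(C)O3)c(NC(=O)CO)c1`) is reached from compound 2 by one change: hydroxy in place of bromo on a saturated chain carbon bound to a carbonyl carbon. In words, this is hydroxy in place of bromo on a saturated chain carbon bound to a carbonyl carbon.

Among the compounds with values here, one measured step bears on it, the same exchange on the core of compound 1: a 5.1-fold lower number from compound 1 to compound 3 (0.71 log units; beyond the scatter), a modest step beyond the scatter. Within the data shown here, the core of compound 2 differs, and no second pair tests whether the step carries over, so the range is kept wide. Going by that single step, a drop of similar size toward a lower number is expected in this assay. The expected change is a 5.1-fold lower number from compound 2 to compound 4 (0.70 log units; beyond the scatter). For compound 4 the estimate is 370 nM, with an expected range of 170 nM to 800 nM.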

Compound 4, half-maximal inhibitory concentration: 130 nM
Compound 4: the middle estimate sits 2.8-fold (0.45 log units) above what was measured; the measured number lies below the stated range.
By their numbers in this assay, from the lowest: compound 4; then compound 3; then compounds 2 and 1 (each within the scatter of the next).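

In this assay, hydroxy in place of bromo on a saturated chain carbon bound to a carbonyl carbon now lowers the number on two cores, so the direction holds in both pairs. The bromo compounds, compound 1 and compound 2, lie within the scatter of each other and do not separate the cores, whereas the printed values do separate the hydroxy compounds: compound 3 gives 420 nM and compound 4 gives 130 nM. The step of a 14-fold lower number from compound 2 to compound 4 (1.16 log units; beyond the scatter) shows that the size of the exchange does not carry over unchanged from one core to the other: the same change on two cores in this assay, a 5.1-fold lower number (0.71 log units; beyond the scatter) from compound 1 to compound 3 and a 14-fold lower number (1.16 log units; beyond the scatter) from compound 2 to compound 4, 2.8-fold (0.45 log units) apart, beyond the scatter of two such steps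

Open, on these data alone, is whether an amine on the same carbon, or a longer chain carrying the hydroxy, would follow the hydroxy compounds. Also open, as far as these compounds go, is whether the difference between the two cores would persist with those groups.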